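From Cyclohexyl Back to Propyl on the Amide Carbonyl

The source may hold more compounds than are shown below. What is called first, only, known or untested is meant among the compounds shown, and "the series" means these compounds.

For the measured compounds named here, in a functional assay on SK-BR-3 cells (Homo sapiens) for antiproliferative activity (on this read-out lower numbers stand for stronger inhibition and higher numbers for weaker inhibition), compound 2 `CO[C@@H]1[C@@H](O)[C@@H](O)[C@H](Oc2ccc3cc(NC(=O)C4CCCCC4)c(=O)oc3c2C)OC1(C)C` gives 46800 nM, the only true number so far. Compound 1 `CO[C@@H]1[C@@H](O)[C@@H](O)[C@H](Oc2ccc3cc(NC(C)=O)c(=O)oc3c2C)OC1(C)C` is reported only as a limit, > 900000 nM. Compound 3 `CCCC(=O)Nc1cc2ccc(O[C@@H]3OC(C)(C)[C@H](OC)[C@@H](O)[C@H]3O)c(C)c2oc1=O` has not yet been measured. It differs from compound 2 as follows: propyl in place of cyclohexyl on a carbonyl carbon. Going by the values given here, one measured step bears on this change, at the same place: an at least 19-fold lower number from compound 1 to compound 2 (1.28 log units; beyond the scatter). That step is large and beyond the scatter, and it came with cyclohexyl in place of methyl. Propyl is neither of those two groups, so compound 3 is expected to give back part of that gain, not all of it, with a higher number in this assay. The expected move is a 3.4-fold higher number from compound 2 to compound 3 (0.53 log units; beyond the scatter). Compound 3 is estimated at 160000 nM, within a range of 50000 nM to 600000 nM.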

Compound 3, half-maximal inhibitory concentration: 313000 nM
Beside the measured number, compound 3's estimate is 2.0-fold (0.29 log units) below it, and the stated range covers the measured number.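

In this assay, propyl in place of cyclohexyl on the carbonyl carbon brings a 6.7-fold higher number from compound 2 to compound 3 (0.83 log units; beyond the scatter), so compound 2 keeps the lowest number of the three compounds. Propyl still improves on the methyl of compound 1, with an at least 2.8-fold lower number from compound 1 to compound 3 (0.45 log units; beyond the scatter), which places the three groups in one order at this position, with the cyclohexyl ring ahead of the open chain. Compound 1 is reported only as a limit, so that last step has an open end: the limit of > 900000 nM in this assay, at which 1 of the 3 values shown sits.

The compounds shown leave open whether a longer chain such as hexyl would match cyclohexyl, or whether the ring itself sets the difference. They also say nothing about how a phenyl ring or a chain ending in an amine would behave on the same carbonyl carbon.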